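Swapping trifluoromethyl for chloro on compound 2

The compounds below may be only part of what the source reports. "The series", "measured", "known", "first", "only" and "open" are said of these compounds alone.

Compound 1 `COc1cc2cc(Oc3ccc(NC(=O)Nc4cccc(C(F)(F)F)c4)cc3)c(C)nc2cc1OC` gives 28200 nM in a functional assay on BT-549 cells (Homo sapiens) for inhibition, read by sulforhodamine B assay, with a stated time of 48 h (on this read-out higher numbers stand for lower toxicity in this test and lower numbers for higher toxicity in this test), and compound 2 `COc1cc2cc(Oc3ccc(NC(=O)Nc4ccc(Cl)c(C(F)(F)F)c4)cc3)c(C)nc2cc1OC` gives 20500 nM. Within the data shown here, compound 2 stands at the end of the only measured step, a 1.4-fold lower number from compound 1 to compound 2 (0.14 log units; within the scatter), which lies within the scatter, so the two compounds are effectively alike on this read-out. Compound 3 `COc1cc2cc(Oc3ccc(NC(=O)Nc4ccc(Cl)c(Cl)c4)cc3)c(C)nc2cc1OC` differs from compound 2 by chloro in place of trifluoromethyl on an aromatic carbon. Among the measured compounds shown here, no measured step replaces a trifluoromethyl group by chloro, and the single known step changed nothing beyond the scatter. The step is therefore expected to be a 1.1-fold higher number from compound 2 to compound 3 (0.03 log units; within the scatter). Compound 3 is estimated at 22000 nM, with a range from 9000 nM to 55000 nM.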

Compound 3, concentration lethal to 50% of the cells: 51600 nM
For compound 3 the middle estimate is 2.3-fold (0.37 log units) below the measured one; low and high end bracket the measured number.
By their numbers in this assay, from the lowest: compounds 2, 1 and 3 (each within the scatter of the next, the first and the last beyond it).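

Among these compounds, at this place, on an aromatic carbon ortho to a chloro group and meta to a large group, chloro in place of trifluoromethyl gives a 2.5-fold higher number from compound 2 to compound 3 (0.40 log units; beyond the scatter) in this assay, the first step here beyond the scatter, towards lower toxicity in this test. The wider change to 3,4-dichlorophenyl gives a 1.8-fold higher number from compound 1 to compound 3 (0.26 log units; within the scatter), so compound 3 and compound 1 remain alike on this read-out. No evidence is available on what lies behind the step.

The compounds shown leave open how a nitrile or an amine on this carbon would read, and whether the step from trifluoromethyl to chloro would hold on other compounds.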